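A few compounds are considered here, and "the series" means these few. Any claim that something is new, unique, unknown or untested is made for them only; others in the source may bear on it.

Going by the values given here, in a physicochemical assay for solubility, read by HPLC, in phosphate buffer, measured as kinetic solubility, at pH 7.4 (a higher number here means a more soluble compound, a lower number a less soluble compound), three compounds have numbers so far. Compound 1 `Cc1ccc(-c2ccc(Cl)cc2)n1-c1ccc(S(N)(=O)=O)cc1` gives 6100 nM, and compound 2 `CCC(=O)c1cc(-c2ccc(F)cc2)n(-c2ccc(S(N)(=O)=O)cc2)c1C` gives 29300 nM. Compound 3 `CCC(=O)c1cc(-c2ccc(S(N)(=O)=O)cc2)n(-c2ccccc2Cl)n1` gives 4700 nM, which is within the usual scatter of compound 1 and clearly lower than compound 2. The next compound, compound 4 `CCC(=O)c1cc(-c2ccc(S(N)(=O)=O)cc2)n(-c2ccc(Cl)cn2)n1`, differs from compound 3 in one place: 5-chloropyridin-2-yl in place of 2-chlorophenyl on an aromatic nitrogen. Among the compounds with values here, no measured pair differs in only one place, so the data offer no direct guide to this change. The expected step is small and upward, a 1.3-fold higher number from compound 3 to compound 4 (0.11 log units; within the scatter), and may stay within the scatter. For compound 4 the estimated value is 6000 nM, with an expected range from 2000 nM to 18000 nM.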

Compound 4, solubility: 33700 nM
The estimate for compound 4 lay 5.6-fold (0.75 log units) below the measured number, outside the stated range (above it).
By their numbers in this assay, from the lowest: compounds 3 and 1 (each within the scatter of the next); then compounds 2 and 4 (each within the scatter of the next).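

In this assay, going by these compounds alone, the first comparison that differs in one place gives a 7.2-fold higher number from compound 3 to compound 4 (0.86 log units; beyond the scatter), with 5-chloropyridin-2-yl in place of 2-chlorophenyl on an aromatic nitrogen. The swap keeps the heavy-atom count the same, yet the number moves beyond the scatter, and the entering group carries a ring nitrogen counted as a hydrogen-bond acceptor. No measurement shown here explains the step. The swap alters both the ring nitrogen and the chlorine's place, so the compounds leave open what a 4-chlorophenyl or a plain pyridin-2-yl would give here.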